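A Methoxymethyl Group Placed on the Fused Ring System

The source may hold more compounds than are shown below. What is called first, only, known or untested is meant among the compounds shown, and "the series" means these compounds.

Of the compounds shown here, three with a shared core have been measured in an assay on tissue (HeLa cells) for inhibition of Indoleamine 2,3-dioxygenase 1 (Homo sapiens), read by spectrophotometry; a lower number here means a stronger inhibitor, a higher number a weaker inhibitor. Compound 1 `O/N=C(/Nc1cccc(F)c1)c1ccc2occc2c1` gives 20000 nM. Compound 2 `O/N=C(/Nc1cccc(Br)c1)c1ccc2occc2c1` gives 1100 nM, and compound 3 `O/N=C(/Nc1ccc(F)c(Br)c1)c1ccc2occc2c1` gives 2600 nM. The step of an 18-fold lower number from compound 1 to compound 2 (1.26 log units; beyond the scatter) is large, and the step of a 2.4-fold higher number from compound 2 to compound 3 (0.37 log units; beyond the scatter) is modest. Compound 2 therefore stands lowest of the three numbers, with compound 3 nearest to it and compound 1 furthest away.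

Compound 4 `COCc1cc2cc(/C(=N\O)Nc3cccc(Br)c3)ccc2o1` differs from compound 2 by methoxymethyl in place of hydrogen on an aromatic carbon. Both measured steps changed groups on the ring that carries the fluoro or bromo substituent, on the other side of the molecule, so neither of them bears directly on a change at this place of the fused ring system. Among the compounds with values here, with no measured step to lean on, the expectation is that the number for compound 4 stays close to that of compound 2, and the expected step of a 1.4-fold higher number from compound 2 to compound 4 (0.13 log units; within the scatter) is taken to lie within the usual scatter. The estimated value for compound 4 in this assay is 1500 nM, with a range from 400 nM to 6000 nM to allow for an effect in either direction.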

Compound 4, half-maximal inhibitory concentration: 2500 nM
The estimate for compound 4 lay 1.7-fold (0.22 log units) below the measured number; measured number inside the range.
By their numbers in this assay, from the lowest: compound 2; then compounds 4 and 3 (each within the scatter of the next); then compound 1.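

At this place, on the aromatic carbon next to the ring oxygen, this assay gives a 2.3-fold higher number from compound 2 to compound 4 (0.36 log units; beyond the scatter) when methoxymethyl replaces hydrogen, so the added group makes the number somewhat worse but does not abolish inhibition. This is the only change shown on the five-membered aromatic ring, and it is clearly smaller than an 18-fold lower number from compound 1 to compound 2 (1.26 log units; beyond the scatter) on the other side of the molecule, where swapping one halogen for another had a far larger effect. Nothing measured here bears on why the number rises with this change, so the result records an effect without offering an explanation.

One step cannot show whether the rise belongs to methoxymethyl in particular or would follow any group at this carbon: a plain methyl, a hydroxymethyl, an amine, a carboxylic acid or a longer ether chain could each move the number in either direction. On these data alone, it also remains open whether methoxymethyl would have an effect of similar size on a compound with a different ring substituent, such as the bromo and fluoro pair of compound 3.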